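Swapping a dimethylaminophenyl for a methylindolyl arm

This account rests on a few compounds, and the source may have more. Where it says the series, first, only, none or still open, it means among the compounds named here.

Compound 1 `COc1ccc(-c2cc3nccc(-c4cc(OC)c(OC)c(OC)c4)n3n2)cc1N` gives 283 nM in a functional assay on HeLa cells (Homo sapiens) for inhibition, read by CCK-8 assay, with a stated time of 48 h; a higher number here means a weaker inhibitor, a lower number a stronger inhibitor.
Compound 2 `COc1cc(-c2ccnc3cc(-c4ccc(C(C)=O)cc4)nn23)cc(OC)c1OC` gives 1810 nM.
Compound 3 `COc1cc(-c2ccnc3cc(-c4ccc(N(C)C)cc4)nn23)cc(OC)c1OC` gives 378 nM.

Among these three numbers compound 3 stands second highest; its nearest neighbour is compound 1, and their values lie within the scatter of each other, whereas compound 2 sits further off, as the step of a 4.8-fold lower number from compound 2 to compound 3 (0.68 log units; beyond the scatter) shows. Compound 4 `COc1cc(-c2ccnc3cc(-c4ccc5c(ccn5C)c4)nn23)cc(OC)c1OC` is not yet measured. It differs from compound 3 in one place: 1-methyl-1H-indol-5-yl in place of 4-(dimethylamino)phenyl on an aromatic carbon.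

Going by the values given here, the steps that bear on this change are those that alter the same aryl arm. The step of a 1.3-fold higher number from compound 1 to compound 3 (0.13 log units; within the scatter) was small, and the step of a 6.4-fold higher number from compound 1 to compound 2 (0.81 log units; beyond the scatter) was modest, as was a 4.8-fold lower number from compound 2 to compound 3 (0.68 log units; beyond the scatter). Changes on this arm have therefore moved the number by at most a modest amount in either direction, and no measured step tells how a fused bicyclic arm behaves. Compound 4 is accordingly expected to land close to compound 3, with the step of a 1.2-fold higher number from compound 3 to compound 4 (0.08 log units; within the scatter) estimated to stay within or barely beyond the scatter. The estimate for compound 4 is 450 nM, ranging from 150 nM to 1400 nM.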

Compound 4, half-maximal inhibitory concentration: 19 nM
Compound 4: middle estimate off by 24-fold (1.37 log units), on the high side, and the stated range ends above it.
By their numbers in this assay, from the lowest: compound 4; then compounds 1 and 3 (each within the scatter of the next); then compound 2.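

Placing 1-methyl-1H-indol-5-yl on this aromatic carbon gave a 20-fold lower number from compound 3 to compound 4 (1.30 log units; beyond the scatter) and a 15-fold lower number from compound 1 to compound 4 (1.17 log units; beyond the scatter) and also a 95-fold lower number from compound 2 to compound 4 (1.98 log units; beyond the scatter) in this assay, all large steps, whereas the earlier exchanges of this arm had been modest at most. The single-ring arms 3-amino-4-methoxyphenyl and 4-(dimethylamino)phenyl lay within the scatter of each other, so only the fused arm showed that this position can give much lower numbers. Nothing in the data shown explains the gain.

On these data alone, it remains open whether the gain belongs to the fused ring or to the methyl on its nitrogen, which an indol-5-yl bearing hydrogen or a longer ethyl chain there could separate. As far as these compounds go, whether other fused arms, such as benzofuran or quinoline, would behave alike is also open.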